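Swapping pyridin-3-yl for pyridin-2-yl on compound 1

The compounds below may be only part of what the source reports. "The series", "measured", "known", "first", "only" and "open" are said of these compounds alone.

Three compounds have been measured so far in an ADME assay on MT4 cells (Homo sapiens) for cytotoxicity, with a stated time of 5 days (on this read-out lower numbers stand for higher toxicity in this test and higher numbers for lower toxicity in this test), and each result is a limit
compound 1 `CC(C)(C)C#Cc1cc(N(C(=O)[C@H]2CC[C@H](C)CC2)[C@H]2CC[C@H](Oc3cccnc3)CC2)c(C(=O)O)s1` gives > 20000 nM as a limit
compound 2 `CC(C)(C)C#Cc1cc(N(C(=O)[C@H]2CC[C@H](C)CC2)[C@H]2CC[C@@H](Oc3cccnc3)CC2)c(C(=O)O)s1` gives > 20000 nM as a limit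
compound 3 `CC(C)N(C(=O)[C@H]1[C@@H]2CCCC[C@@H]21)c1cc(C#CC(C)(C)C)sc1C(=O)O` gives > 20000 nM as a limit

Compound 1 stands at > 20000 nM in this assay and this is a limit, not a number. The overall picture is the limit of > 20000 nM in this assay, at which 3 of the 3 values shown sit, and so compound 1 cannot be ranked against the others.

Compound 4 `CC(C)(C)C#Cc1cc(N(C(=O)[C@H]2CC[C@H](C)CC2)[C@H]2CC[C@H](Oc3ccccn3)CC2)c(C(=O)O)s1` has not yet been measured. Its change from compound 1 is pyridin-2-yl in place of pyridin-3-yl on an oxygen on a saturated carbon and the core stays the same.

Going by the values given here, only one measured step bears on this change, and it is a step that the two limits leave unreadable from compound 1 to compound 2 with no size to carry over. That pair is a comparison of shape alone, as the fact that compounds 1 and 2 differ only in the configuration as drawn makes clear, and neither of its members has the pyridin-2-yl group. The data therefore offer no measured effect of this swap. The expectation rests on compound 1 with its > 20000 nM as a limit. No step beyond the scatter is expected in this assay and no direction is predicted. The estimated change is a step that the limit leaves unreadable from compound 1 to compound 4 as an expected step. For compound 4 the expected value is 22000 nM with an estimated range from 12000 nM to 40000 nM and a limit is the likeliest report.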

Compound 4, half-maximal cytotoxic concentration: > 20000 nM
Compound 4: no number, only a limit; the forecaster's own chance of this, stated with the estimate: 85%; the middle value lies beyond the limit too.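

The step from compound 1 to compound 4 cannot be read: each of the two results in this assay is a limit, not a number. The compounds shown leave open whether pyridin-2-yl in place of pyridin-3-yl changes this read-out at all, and at what concentration any of the four compounds would harm these cells.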